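A few compounds are considered here, and "the series" means these few. Any claim that something is new, unique, unknown or untested is made for them only; others in the source may bear on it.

In a functional assay on thoracic aorta (Rattus norvegicus, strain Wistar), with a stated time of 15 min (a lower number here means that less compound is needed, a higher number that more compound is needed for the effect), compound 1 (`COc1ccc(Cl)cc1C(C)NC(=O)NS(=O)(=O)c1ccccc1`) gives > 300000 nM, a limit of the assay and not a number. Compound 2 (`COc1ccc(Cl)cc1C(C)NC(=O)NS(=O)(=O)c1ccc(Cl)cc1`) gives > 300000 nM, which is also a limit. Compound 3 (`COc1ccc(Br)cc1C(C)NC(=O)NS(=O)(=O)c1ccccc1`) gives > 300000 nM, again a limit. Among the compounds with values here, compound 3 therefore stands on no number, and the series so far shows (the limit of > 300000 nM in this assay, at which 3 of the 3 values shown sit).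

Compound 4 (`COc1ccc(Br)cc1C(C)NC(=O)NS(=O)(=O)c1ccc(Cl)cc1`) differs from compound 3 by chloro in place of hydrogen on an aromatic carbon. In words, chloro takes the place of hydrogen on an aromatic carbon, para to a large group, so that phenyl becomes 4-chlorophenyl.

Within the data shown here, the closest precedent is the same exchange, which gave a step that the two limits leave unreadable from compound 1 to compound 2. The exchange of bromo for chloro gave a step that the two limits leave unreadable from compound 1 to compound 3 and bears on the change only indirectly, as the two compounds at its ends carry no added chloro. Neither step has a size that can be carried over. Resting on a step that the two limits leave unreadable from compound 1 to compound 2, no step beyond the scatter is expected in this assay, in either direction, and a reading at the same limit is the likeliest outcome. The estimated step is a number no higher from compound 3 to compound 4 (the limit leaves the size open). For compound 4 the estimate is 300000 nM, with an expected range of 100000 nM to 600000 nM.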

Compound 4, half-maximal effective concentration: 80900 nM
Compound 4: middle estimate off by 3.7-fold (0.57 log units), on the high side, and the stated range ends above it.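

In this assay, chloro in place of hydrogen, turning phenyl into 4-chlorophenyl, gives an at least 3.7-fold lower number from compound 3 to compound 4 (0.56 log units; beyond the scatter), so this position can respond when bromo is present. With 4-chlorophenyl held fixed, bromo in place of chloro gives an at least 3.7-fold lower number from compound 2 to compound 4 (0.56 log units; beyond the scatter), which shows that the halogen on the other side of the sulfonylurea also matters once the chloro is in place. The two exchanges produce a measured number only in combination, and compound 4 is the only compound here to leave the limit: the limit of > 300000 nM in this assay, at which 3 of the 4 values shown sit.

On these data alone, the steps starting at compound 1 cannot be read, and the two steps to compound 4 give only a minimum size, so it remains open how much each exchange contributes alone and whether their contributions simply add. Also open, as far as these compounds go, is how the position responds to a fluoro, a methyl, an amine or a carboxylic acid in place of the chloro of 4-chlorophenyl.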